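Neopentyl amide in place of the carbamate at the pyrrolidine nitrogen

This account rests on a few compounds, and the source may have more. Where it says the series, first, only, none or still open, it means among the compounds named here.

Measured so far:
compound 1 `CC(C)(C)OC(=O)N1CCC[C@H]1C(=O)N1CCC(NS(=O)(=O)c2cc(S(=O)(=O)c3ccccc3)ccc2C(F)(F)F)CC1`, 60 nM
compound 2 `CC(C)(C)OC(=O)N1CCC[C@@H]1C(=O)N1CCC(NS(=O)(=O)c2cc(S(=O)(=O)c3ccccc3)ccc2C(F)(F)F)CC1`, 120 nM
compound 3 `CC(C)(C)OC(=O)N1C(=O)CC[C@H]1C(=O)N1CCC(NS(=O)(=O)c2cc(S(=O)(=O)c3ccccc3)ccc2C(F)(F)F)CC1`, 130 nM

In an assay on isolated protein for binding affinity to secreted frizzled-related protein 1 (Homo sapiens), read by fluorescence (on this read-out lower numbers stand for stronger inhibition and higher numbers for weaker inhibition), compound 2 gives 120 nM, the second highest of the three numbers; compound 3 gives 130 nM and compound 1 gives 60 nM, and the step of a 2.0-fold higher number from compound 1 to compound 2 (0.30 log units; within the scatter) is within the scatter. Both compounds 1 and 2 share all atoms and bonds and differ only in the drawn configuration (the fact that compounds 1 and 2 differ only in the configuration as drawn). Compound 4 `CC(C)(C)CC(=O)N1CCC[C@H]1C(=O)N1CCC(NS(=O)(=O)c2cc(S(=O)(=O)c3ccccc3)ccc2C(F)(F)F)CC1` differs from compound 2 in one place: 1-(neopentylcarbonyl)pyrrolidin-2-yl in place of 1-(tert-butoxycarbonyl)pyrrolidin-2-yl on a carbonyl carbon. For the measured compounds named here, no measured step touches this position; the only measured step is the configurational one, and it stays within the scatter. No basis is seen here for a step beyond the scatter in this assay in either direction. Compound 4 is therefore expected near compound 2, at an estimated 120 nM with a range from 40 nM to 400 nM, meaning an expected step of no change at the digits printed from compound 2 to compound 4 (within the scatter).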

Compound 4, half-maximal inhibitory concentration: 20 nM
Estimate against measurement, compound 4: 6.0-fold (0.78 log units) above, outside the stated range (below it).
By their numbers in this assay, from the lowest: compound 4; then compounds 1, 2 and 3 (each within the scatter of the next, the first and the last beyond it).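

Neopentyl in place of tert-butoxy on a carbonyl carbon gives a 3.0-fold lower number from compound 1 to compound 4 (0.48 log units; beyond the scatter) in this assay, so this position moves the read-out beyond the scatter, which the configurational step did not. Carbon in place of the tert-butoxy oxygen costs nothing here in binding. The wider step, a 6.0-fold lower number from compound 2 to compound 4 (0.78 log units; beyond the scatter), also carries a difference in drawn configuration: the fact that compounds 1 and 2 differ only in the configuration as drawn

Going by these compounds, whether the lower number belongs to the neopentyl group as a whole or to the loss of that oxygen stays open. Also open, on these data alone, is what an amine, a carboxylic acid or a longer chain would give on this carbonyl carbon.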